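Growing an Ether on the Core: Hydrogen to Phenethyloxy

The source may report more compounds than this note shows. Statements on the series, on what has been measured and on what is new or still open speak of the compounds shown alone.

The two measured compounds were tested in an assay on isolated protein for inhibition of serine protease 1 (Homo sapiens), read by fluorescence; on this read-out higher numbers stand for weaker inhibition and lower numbers for stronger inhibition.
Compound 1 `CNC(=O)[C@@H]1C[C@H](N2CCc3c(cccc3OC)C2)CN1C(=O)c1ccc(CN)c(OC)c1` gives 100 nM.
Compound 2 `CNC(=O)[C@@H]1C[C@H](N2CCc3ccccc3C2)CN1C(=O)c1ccc(CN)c(OC)c1` gives 490 nM.

For the measured compounds named here, compound 2 has the higher of these two numbers, and the only step available, a 4.9-fold higher number from compound 1 to compound 2 (0.69 log units; beyond the scatter), shows that removing the methoxy from that aromatic carbon weakened inhibition beyond the scatter. Compound 3 `CNC(=O)[C@@H]1C[C@H](N2CCc3c(cccc3OCCc3ccccc3)C2)CN1C(=O)c1ccc(CN)c(OC)c1` is not yet measured; it places a larger ether at the same point, the change being (phenethyloxy in place of hydrogen on an aromatic carbon). Going by the values given here, the one measured step bears directly on this, since it shows that an oxygen-linked group at this position helped in this assay. Whether a much larger group than methoxy helps as much cannot be read from a single pair, so the expectation is a gain of about the same or somewhat smaller size than the loss seen on going from compound 1 to compound 2. Compound 3 is therefore expected to show a 2.7-fold lower number from compound 2 to compound 3 (0.43 log units; beyond the scatter) in this assay, giving an estimated 180 nM, with a likely range of 50 nM to 650 nM.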

Compound 3, half-maximal inhibitory concentration: 3 nM
For compound 3 the middle estimate is 60-fold (1.78 log units) above the measured one; measured number below the stated range.
By their numbers in this assay, from the lowest: compound 3; then compound 1; then compound 2.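

In this assay, the earlier pair showed only that a methoxy on this aromatic carbon does better than hydrogen, whereas phenethyloxy in place of hydrogen gives a 160-fold lower number from compound 2 to compound 3 (2.21 log units; beyond the scatter), so this position accepts a much larger ether and gains far more from it. The comparison with the methoxy compound points the same way: adding benzyl to the saturated carbon bound to the oxygen gives a 33-fold lower number from compound 1 to compound 3 (1.52 log units; beyond the scatter), so most of the gain comes from the part of the group that lies beyond the methoxy. No measurement shown here explains why the larger ether has so strong an effect.

The compounds shown cover only hydrogen, methoxy and phenethyloxy at this place, so it remains open whether the gain depends on the added aromatic ring or simply on chain length, a question that a benzyloxy, an ethoxy or a longer plain alkoxy chain could help to answer. From the compounds shown here alone, it also remains open whether the oxygen link itself matters, which a phenethyl group joined directly through carbon would test.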